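Pyridin-4-yl for pyridin-2-yl on compound 3

The source may hold more compounds than are shown below. What is called first, only, known or untested is meant among the compounds shown, and "the series" means these compounds.

Measured in a functional assay on A498 cells (Homo sapiens) for antiproliferative activity; on this read-out higher numbers stand for weaker inhibition of growth and lower numbers for stronger inhibition of growth:
Compound 1 `c1ccc(-c2cc(-c3ccsc3)cc(-c3ccccn3)n2)nc1`: 0.000097 ug/mL
Compound 2 `c1ccc(-c2cc(-c3ccccn3)nc(-c3ccccn3)c2)cc1`: 0.0025 ug/mL
Compound 3 `c1ccc(-c2cc(-c3cccs3)cc(-c3ccccn3)n2)nc1`: 0.000097 ug/mL

Compound 3 shares the lowest number of the three, with no change at the digits printed from compound 1 to compound 3 (within the scatter), and a 26-fold lower number from compound 2 to compound 3 (1.41 log units; beyond the scatter) sets compound 2 well apart. Compound 4 `c1ccc(-c2cc(-c3cccs3)cc(-c3ccncc3)n2)nc1` carries pyridin-4-yl in place of pyridin-2-yl, next to the ring nitrogen: pyridin-4-yl in place of pyridin-2-yl on an aromatic carbon. For the measured compounds named here, no measured step tests this place. The measured swaps lie elsewhere, yet a 26-fold higher number from compound 1 to compound 2 (1.41 log units; beyond the scatter) shows that one ring swap can matter greatly. With compound 3 already at 0.000097 ug/mL, a higher number seems likelier than a lower one. The expected change is a 100-fold higher number from compound 3 to compound 4 (2.01 log units; beyond the scatter). For compound 4 the estimated value is 0.01 ug/mL, with an expected range from 0.0005 ug/mL to 0.3 ug/mL.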

Compound 4, concentration for 50% growth inhibition: 0.84 ug/mL
The estimate for compound 4 lay 84-fold (1.92 log units) below the measured number; the whole stated range lies below it.
By their numbers in this assay, from the lowest: compounds 1 and 3 (each within the scatter of the next); then compound 2; then compound 4.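

In this assay, pyridin-4-yl in place of pyridin-2-yl gives an 8700-fold higher number from compound 3 to compound 4 (3.94 log units; beyond the scatter), the largest step among these compounds and well beyond the swaps between phenyl and the thiophene groups elsewhere on the core. The two groups hold the same atoms, so this position responds strongly to how those atoms are joined, not only to which atoms are present. No measurement here accounts for this loss of growth inhibition. From the compounds shown here alone, whether pyridin-3-yl would fall nearer compound 3 or compound 4 remains open, as does the effect of an amine on the pyridin-2-yl group.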